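The source may report more compounds than this note shows. Statements on the series, on what has been measured and on what is new or still open speak of the compounds shown alone.

Measured so far:
compound 1, `COc1cc(-c2cc(/C=C/C(=O)c3ccc(Cl)c(Cl)c3)[nH]n2)cc(OC)c1OC`: 1720 nM
compound 2, `COc1ccc(-c2cc(/C=C/C(=O)c3ccc(N)cc3)[nH]n2)cc1OC`: 2800 nM

The two compounds were tested in a functional assay on HOP-62 cells (Homo sapiens) for inhibition, read by sulforhodamine B assay, with a stated time of 48 h; a higher number here means a weaker inhibitor of growth, a lower number a stronger inhibitor of growth. Compound 1 gives 1720 nM, the lowest of the two numbers. Compound 2 gives 2800 nM, a slightly higher number, but the gap between the two lies within the usual scatter of this assay, so neither can be called the stronger inhibitor of growth on these data alone.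

Compound 3, `COc1ccc(C(=O)/C=C/c2cc(-c3cc(OC)c(OC)c(OC)c3)n[nH]2)cc1OC`, has not yet been measured. For the measured compounds named here, it keeps the core of compound 1 and differs from it in one place: 3,4-dimethoxyphenyl in place of 3,4-dichlorophenyl on a carbonyl carbon No step between two measured compounds isolates this change, so the direction has to be judged without a direct precedent. Since compound 1 and compound 2 sit so close despite differing in more than one place, the expected step of a 1.5-fold higher number from compound 1 to compound 3 (0.16 log units; within the scatter) is small and within the scatter, with a slight lean toward a higher number. Compound 3 is therefore estimated at 2500 nM in this assay, with a likely range from 900 nM to 7000 nM.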

Compound 3, concentration for 50% growth inhibition: 1440 nM
The estimate for compound 3 lay 1.7-fold (0.24 log units) above the measured number; measured number inside the range.
By their numbers in this assay, from the lowest: compounds 3, 1 and 2 (each within the scatter of the next).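

In this assay, for the compounds shown here, putting 3,4-dimethoxyphenyl in place of 3,4-dichlorophenyl on a carbonyl carbon gives a 1.2-fold lower number from compound 1 to compound 3 (0.08 log units; within the scatter), the first comparison in this set that isolates a single place. A group carrying chlorine and no hydrogen-bond acceptors gives way to one carrying oxygen and counted with hydrogen-bond acceptors, yet the read-out does not separate compound 1 from compound 3, so this particular exchange on the shared core leaves growth inhibition unresolved. No measurement at hand offers an explanation for this result.

The compounds shown leave open whether any group on this carbonyl carbon would move the number beyond the scatter, for example a carboxylic acid or a dimethylamino group on the phenyl ring, or a pyridine ring in place of the phenyl ring. Compound 2 also carries a different group there, but it differs from compound 1 and from compound 3 in more than one place, so it cannot settle that question.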